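Swapping the bromophenyl arm for a 3-hydroxyphenyl group

A few compounds are considered here, and "the series" means these few. Any claim that something is new, unique, unknown or untested is made for them only; others in the source may bear on it.

compound 1 `COc1cc(NC(C)CCCNC(=O)Nc2cccc(Cl)c2)c2ncccc2c1`: 17000 nM
compound 2 `COc1cc(NC(C)CCCNC(=O)NNC(=O)Nc2ccc(Br)cc2)c2ncccc2c1`: 101000 nM

Among the compounds with values here, in a functional assay on HeLa cells (Homo sapiens) for inhibition, read by MTT assay, with a stated time of 72 h (a higher number here means a weaker inhibitor, a lower number a stronger inhibitor), compound 2 gives 101000 nM, the higher of the two numbers so far, which makes it the weaker inhibitor of the pair. Compound 3 `COc1cc(NC(C)CCCNC(=O)Nc2cccc(O)c2)c2ncccc2c1` has not yet been measured. Going to it from compound 2 means 3-hydroxyphenyl in place of ((4-bromophenyl)carbamoyl)amino on an amide-type nitrogen.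

Within the data shown here, only one measured step bears on this change. It is a 5.9-fold higher number from compound 1 to compound 2 (0.77 log units; beyond the scatter), and it brought in the same ((4-bromophenyl)carbamoyl)amino group, there in place of 3-chlorophenyl. Compound 3 removes that group again, so compound 1 at 17000 nM is the closest guide. Among the measured compounds shown here, no measured compound carries 3-hydroxyphenyl, so the effect of exchanging 3-chlorophenyl for it remains unknown, and the range must stay wide. The expected change is therefore a reversal of similar size, towards a lower number, and a 5.1-fold lower number from compound 2 to compound 3 (0.70 log units; beyond the scatter) is the estimated step. For compound 3 the estimate is 20000 nM, with an expected range of 7000 nM to 60000 nM.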

Compound 3, half-maximal inhibitory concentration: 48000 nM
Compound 3: middle estimate off by 2.4-fold (0.38 log units), on the low side; the range from low to high includes it.
By their numbers in this assay, from the lowest: compound 1; then compound 3; then compound 2.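

Within this assay, hydroxy in place of chloro on an aromatic carbon gives a 2.8-fold higher number from compound 1 to compound 3 (0.45 log units; beyond the scatter) and shows for the first time that this single substituent on the ring can shift the result on its own, with chloro giving the lower number of the two. Exchanging the larger ((4-bromophenyl)carbamoyl)amino group for 3-hydroxyphenyl on the amide-type nitrogen gives a 2.1-fold lower number from compound 2 to compound 3 (0.32 log units; beyond the scatter) and so recovers only part of the earlier rise, leaving compound 3 in the middle of the three compounds, with its steps to both neighbours beyond the scatter. The data offer no independent measurement that could explain either shift.

From the compounds shown here alone, with only chloro and hydroxy to compare, it remains open how a methoxy group, an amine or a carboxylic acid on the same aromatic carbon would read in this assay and whether any of them would give a lower number than chloro. Also open, going by these compounds, is whether a longer chain on the amide-type nitrogen would change the result, and whether the chloro and hydroxy difference would look the same with another group at that nitrogen.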